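Cyclopentyl to Cyclohexyl on an Aromatic Nitrogen

This account rests on a few compounds, and the source may have more. Where it says the series, first, only, none or still open, it means among the compounds named here.

Of the compounds shown here, two built on the same core have been measured. Compound 1 `Cn1c(=O)c2nn(C3CCCC3)nc2n(C)c1=O` is the weaker of them: in an assay on cell membranes from brain for displacement of a labelled ligand from adenosine receptor A1 (Bos taurus) (on this read-out higher numbers stand for weaker inhibition and lower numbers for stronger inhibition), compound 1 gives 110000 nM. Compound 2 `Cn1c(=O)c2c(nnn2C2CCCC2)n(C)c1=O`, which carries its cyclopentyl on a different nitrogen of the core, gives 11000 nM in this assay. For the measured compounds named here, compound 1 therefore stands at the highest of the two numbers, and the gap to compound 2 lies beyond the scatter, but no single-change step between measured compounds is available, so the pair shows only that much.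

Compound 3 `Cn1c(=O)c2nn(C3CCCCC3)nc2n(C)c1=O` is the next compound to be measured. It differs from compound 1 by cyclohexyl in place of cyclopentyl on an aromatic nitrogen. Going by the values given here, nothing among the measured compounds tells how a change of ring size at this position moves the number. In the absence of such a reference, the step from compound 1 to compound 3 is expected to be small, a 1.8-fold lower number from compound 1 to compound 3 (0.26 log units; within the scatter), lying at or near the scatter, with a slight lean toward a lower number. Compound 3 is accordingly estimated at 60000 nM in this assay, within a range from 15000 nM to 250000 nM.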

Compound 3, inhibition constant: 36000 nM
Beside the measured number, compound 3's estimate is 1.7-fold (0.22 log units) above it; low and high end bracket the measured number.
By their numbers in this assay, from the lowest: compound 2; then compound 3; then compound 1.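

In this assay, for the compounds shown here, the position on an aromatic nitrogen of the core of compound 1 proves sensitive to the size of the ring it carries: cyclohexyl in place of cyclopentyl brings a 3.1-fold lower number from compound 1 to compound 3 (0.49 log units; beyond the scatter) and gives the first single-change step in this small set. Neither group carries a hydrogen-bond donor or acceptor, and the only difference between them is a six-membered rather than a five-membered carbon ring, yet this modest step still lies beyond the scatter. No measurement shown here speaks to what lies behind this step.

As far as these compounds go, whether the number would keep falling with a still larger ring such as cycloheptyl, or how it would respond to a phenyl ring, a longer open chain such as n-hexyl or an amine on this nitrogen, remains open. From the compounds shown here alone, it also remains open whether cyclohexyl would bring a similar step on the other nitrogen, the one that carries cyclopentyl in compound 2, as a single step at one position cannot show whether the effect of ring size carries over to another.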